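The compounds below may be only part of what the source reports. "The series", "measured", "known", "first", "only" and "open" are said of these compounds alone.

Notes on the series: in a functional assay on the whole organism (Hindlimb, strain albino) with Mus musculus as the target, in the maximal electroshock model, with a stated time of 0.5 h (a lower number here means that less compound is needed, a higher number that more compound is needed for the effect), compound 1 (`O=C(/C=C/c1ccc(O)cc1)Nc1nc2ccccc2s1`) gives 517 umol/kg and compound 2 (`COc1ccc(/C=C/C(=O)Nc2nc3ccccc3s2)cc1O`) gives 495 umol/kg. These two numbers lie within the scatter of each other, so compound 2 does not stand apart from compound 1, and the series rests on only these two measurements so far. Compound 3 (`COc1ccc(/C=C/C(=O)Nc2nc3ccccc3s2)cc1`) has yet to be measured in this assay. It differs from compound 2 by a single change: hydrogen in place of hydroxy on an aromatic carbon. Within the data shown here, no measured step covers this change. The close values of compound 1 at 517 umol/kg and compound 2 at 495 umol/kg give no ground for expecting a large move, so no shift beyond the scatter is expected, with at most a slight lean toward a lower number. The expected change is a 1.2-fold lower number from compound 2 to compound 3 (0.06 log units; within the scatter). Compound 3 is estimated at 430 umol/kg, with an expected range from 210 umol/kg to 850 umol/kg.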

Compound 3, dose for half-maximal effect: 435 umol/kg
Compound 3: middle estimate off by 1.0-fold (0.01 log units), on the low side, within the range that was stated.
By their numbers in this assay, from the lowest: compounds 3, 2 and 1 (each within the scatter of the next).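

In this assay, the hydroxy group ortho to a methoxy group can be replaced by hydrogen with a 1.1-fold lower number from compound 2 to compound 3 (0.06 log units; within the scatter) as the result, so a free hydroxy at this position is not needed to hold the number at this level. On the other side of the ring, methyl in place of hydrogen on the oxygen gives a 1.2-fold lower number from compound 1 to compound 3 (0.08 log units; within the scatter) and also stays within the scatter, so compound 3 keeps the number without any hydroxy group on the ring. No measurement on hand accounts for this flat outcome.

As far as these compounds go, whether an amine or a carboxylic acid at this position, or a longer alkoxy chain in place of the methoxy group, would move the number beyond the scatter remains open. From the compounds shown here alone, the role of the shared core also remains open, since it is the same in all three compounds.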